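Phenethyl amide tested after three limit-only analogues

The source may hold more compounds than are shown below. What is called first, only, known or untested is meant among the compounds shown, and "the series" means these compounds.

Compound 1, `CN1CC[C@@H](c2ccc(Cl)cc2)[C@H](C(=O)NCc2ccc(CNC(=O)/C=C/c3ccc(Cl)cc3)cc2)C1`: in an assay on a subcellular fraction from brain for inhibition of sodium-dependent dopamine transporter (Rattus norvegicus) (on this read-out lower numbers stand for stronger inhibition and higher numbers for weaker inhibition), compound 1 gives > 2000 nM, which is a limit of the assay.
Compound 2, `CN1CC[C@@H](c2ccc(Cl)cc2)[C@H](C(=O)NCc2ccc(CNC(=O)c3cccc(C(F)(F)F)c3)cc2)C1`: compound 2 gives > 5000 nM, a limit.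
Compound 3, `CN1CC[C@@H](c2ccc(Cl)cc2)[C@H](C(=O)NCc2ccc(CNC(=O)c3cccc(Cl)c3)cc2)C1`: compound 3 gives > 4000 nM, a limit.

Compound 3 thus stands only at a limit, and its two companions stand at limits as well, so none of the three values is a number (the limit of > 2000 nM in this assay, at which 1 of the 3 values shown sits, (the limit of > 4000 nM in this assay, at which 1 of the 3 values shown sits), (the limit of > 5000 nM in this assay, at which 1 of the 3 values shown sits)). The steps a step that the two limits leave unreadable from compound 1 to compound 2, a step that the two limits leave unreadable from compound 1 to compound 3 and a step that the two limits leave unreadable from compound 2 to compound 3 cannot be read. Compound 4, `CN1CC[C@@H](c2ccc(Cl)cc2)[C@H](C(=O)NCc2ccc(CNC(=O)CCc3ccccc3)cc2)C1`, differs from compound 3 by phenethyl in place of 3-chlorophenyl on a carbonyl carbon. Going by the values given here, no measured step bears readably on this change; three different groups on that carbonyl carbon all left the value at a limit. The expected step that the limit leaves unreadable from compound 3 to compound 4 is accordingly no readable change. Compound 4 is estimated at 6000 nM, within 1500 nM to 25000 nM, most likely reported again only as a limit.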

Compound 4, inhibition constant: > 2000 nM
Compound 4: no number, only a limit; the forecaster's own chance of this, stated with the estimate: 75%; the middle value lies beyond the limit too.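

Going by these compounds alone, compound 4, like compound 1, compound 2 and compound 3, stands only at a limit, so no step from those three compounds to compound 4 can be read. The compounds shown leave open whether any group on that carbonyl carbon gives a number rather than a limit in this assay.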